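Restoring a methylene-linked amine on the oxadiazole of compound 3

A few compounds are considered here, and "the series" means these few. Any claim that something is new, unique, unknown or untested is made for them only; others in the source may bear on it.

Of the compounds shown here, three sharing a core have been measured in an assay on HeLa cells for inhibition of sphingosine-1-phosphate transporter SPNS2 (Mus musculus), read by LC-MS, tested at 2 uM; a lower number here means less inhibition, a higher number more inhibition at the concentration tested (going by the name of the read-out). Compound 1 `CCCCCCCCCCc1ccc(-c2noc(CN)n2)cc1` gives 62%. Compound 2 `CCCCCCCCCCc1ccc(-c2noc(CC3CNC3)n2)cc1`, with azetidin-3-yl in place of amino on a saturated chain carbon bound to an aromatic carbon, gives 63%, a step of a number 1 percentage points higher from compound 1 to compound 2 (within the scatter). Compound 3 `CCCCCCCCCCc1ccc(-c2noc([C@H]3CCCN3)n2)cc1`, carrying pyrrolidin-2-yl on the aromatic carbon, gives 12%, the lowest of the three numbers; its nearest neighbour is compound 1 and its furthest compound 2, both beyond the scatter.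

The next compound, compound 4 `CCCCCCCCCCc1ccc(-c2noc(CN3CCNCC3)n2)cc1`, differs from compound 3 as follows: (piperazin-1-yl)methyl in place of pyrrolidin-2-yl on an aromatic carbon. Among the compounds with values here, the steps that bear on this change are those in which pyrrolidin-2-yl entered: a number 50 percentage points lower from compound 1 to compound 3 (beyond the scatter) and a number 51 percentage points lower from compound 2 to compound 3 (beyond the scatter), both large losses when the aminomethyl or (azetidin-3-yl)methyl group was replaced by pyrrolidin-2-yl. Within the data shown here, compound 4 again places a saturated chain carbon between the aromatic carbon and the amine, as in compound 1 and compound 2, so the expectation is that the loss seen for compound 3 is largely reversed and the number rises substantially, though the piperazin-1-yl ring itself has no measured precedent here.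

Compound 4 is therefore expected to give an estimated 55% in this assay, within a range of 30% to 75%, which corresponds to an expected step of a number 43 percentage points higher from compound 3 to compound 4 (beyond the scatter).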

Compound 4, a percentage reported as inhibition, at one concentration (the size of the read-out at that concentration, not a potency): 19%
Beside the measured number, compound 4's estimate is 36 percentage points above it; the whole stated range lies above it.
By their numbers in this assay, from the lowest: compounds 3 and 4 (each within the scatter of the next); then compounds 1 and 2 (each within the scatter of the next).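

In this assay, a saturated chain carbon on this aromatic carbon proved not enough on its own to match compound 1 and compound 2: (piperazin-1-yl)methyl in place of pyrrolidin-2-yl gives a number 7 percentage points higher from compound 3 to compound 4 (within the scatter), leaving these two compounds together at the low end. The group carried by that chain carbon therefore counts, since piperazin-1-yl in place of amino gives a number 43 percentage points lower from compound 1 to compound 4 (beyond the scatter) and piperazin-1-yl in place of azetidin-3-yl gives a number 44 percentage points lower from compound 2 to compound 4 (beyond the scatter), whereas azetidin-3-yl in place of amino had given only a number 1 percentage points higher from compound 1 to compound 2 (within the scatter). No supporting data are available to explain why these groups differ.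

On these data alone, it remains open whether other groups on the same saturated chain carbon, such as dimethylamino, piperidin-4-yl or morpholin-4-yl, would stand with compound 1 and compound 2 or with compound 4. The compounds also leave open how the opposite enantiomer of the pyrrolidin-2-yl group in compound 3 would read in this assay, and whether a group with the amine carried further along a longer chain would do the same.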